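A few compounds are considered here, and "the series" means these few. Any claim that something is new, unique, unknown or untested is made for them only; others in the source may bear on it.

Measured so far in an ADME assay on HEK293 cells (Homo sapiens) for cytotoxicity, read by MTT assay, with a stated time of 48 h; on this read-out lower numbers stand for stronger inhibition and higher numbers for weaker inhibition
Compound 1 `COc1ccc(/C=C2/S/C(=N/c3ccccc3)N(Cc3ccncc3)C2=O)cc1OC` gives 171000 nM
Compound 2 `COc1ccc(OC)c(/C=C2/S/C(=N/c3ccccc3)N(Cc3ccncc3)C2=O)c1` gives 80100 nM

Of these two, compound 2 at 80100 nM holds the lower number in this assay and compound 1 holds the higher one. Among the measured compounds shown here, the single measured step is a 2.1-fold lower number from compound 1 to compound 2 (0.33 log units; beyond the scatter) and it is modest, though beyond the scatter.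

Compound 3 `O=C1/C(=C\c2cccc(O)c2)S/C(=N/c2ccccc2)N1Cc1ccncc1` has not yet been measured. Its difference from compound 2 is 3-hydroxyphenyl in place of 2,5-dimethoxyphenyl on a double-bonded chain carbon bound to a double-bonded ring carbon and it amounts to 3-hydroxyphenyl in place of 2,5-dimethoxyphenyl on a double-bonded chain carbon bound to a double-bonded ring carbon.

For the measured compounds named here, no measured step replaces a dimethoxyphenyl with a 3-hydroxyphenyl, so the one step available bears on this change only loosely. Going by the values given here, that step, a 2.1-fold lower number from compound 1 to compound 2 (0.33 log units; beyond the scatter) and nothing more, is the sole guide to how far a change at this place moves the number. A small shift is therefore expected, upward if anything. The expected step is a 1.2-fold higher number from compound 2 to compound 3 (0.10 log units; within the scatter) as estimated here. Compound 3 is expected at an estimated 100000 nM with a range from 40000 nM to 250000 nM in this estimate.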

Compound 3, half-maximal inhibitory concentration: 150000 nM
Beside the measured number, compound 3's estimate is 1.5-fold (0.18 log units) below it; measured number inside the range.
By their numbers in this assay, from the lowest: compounds 2, 3 and 1 (each within the scatter of the next, the first and the last beyond it).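

In this assay, putting 3-hydroxyphenyl on a double-bonded chain carbon bound to a double-bonded ring carbon gives a 1.9-fold higher number from compound 2 to compound 3 (0.27 log units; within the scatter) in place of 2,5-dimethoxyphenyl and a 1.1-fold lower number from compound 1 to compound 3 (0.06 log units; within the scatter) in place of 3,4-dimethoxyphenyl, so neither exchange can be told apart from repeat scatter. The earlier compounds shown here showed only that moving between two dimethoxyphenyl groups can shift the number modestly, whereas these steps show that a smaller group carrying a hydrogen-bond donor, with a single oxygen in place of two, leaves the number at this place within the scatter of both dimethoxyphenyl compounds, and only those two compounds stand apart from each other. Nothing available explains why these numbers fall as they do.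

The compounds shown leave open whether the hydroxyl group itself matters here, as the 3-hydroxyphenyl group differs from each dimethoxyphenyl group in more than one respect. They also leave open whether a phenyl group carrying an amine or a carboxylic acid at this place would move the number beyond the scatter, or whether every change here stays this small.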